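Extending the Methyl of Compound 3 to Propyl

The compounds below may be only part of what the source reports. "The series", "measured", "known", "first", "only" and "open" are said of these compounds alone.

Compound 1 `CCCC(=O)Nc1cccc(NC(=O)COc2ccc3c(=O)ccoc3c2)c1` in an assay on isolated protein for inhibition of Rho-associated protein kinase 2 (Homo sapiens), read by scintillation counting, radiometric assay and 33P incorporation, with a stated time of 40 min, in the presence of a further agent that is not named here; on this read-out lower numbers stand for stronger inhibition and higher numbers for weaker inhibition: 176 nM
Compound 2 `O=C(COc1ccc2c(=O)ccoc2c1)Nc1cccc(NC(=O)c2ccccc2)c1` in this assay: 16 nM
Compound 3 `Cc1ccc(C(=O)Nc2cccc(NC(=O)COc3ccc4c(=O)ccoc4c3)c2)cc1` in this assay: 22 nM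

Compound 3 sits close to compound 2 and far from compound 1. The step of a 1.4-fold higher number from compound 2 to compound 3 (0.14 log units; within the scatter) is within the scatter, so the two cannot be told apart on these numbers. Against compound 1 the gap is clear: an 8.0-fold lower number from compound 1 to compound 3 (0.90 log units; beyond the scatter), and the related step of an 11-fold lower number from compound 1 to compound 2 (1.04 log units; beyond the scatter) points the same way.

Compound 4 `CCCc1ccc(C(=O)Nc2cccc(NC(=O)COc3ccc4c(=O)ccoc4c3)c2)cc1` differs from compound 3 by ethyl in place of hydrogen on a saturated chain carbon bound to an aromatic carbon. For the measured compounds named here, the only measured step that touches this part of the molecule is the one from hydrogen to methyl on the aromatic carbon, a 1.4-fold higher number from compound 2 to compound 3 (0.14 log units; within the scatter), which stayed within the scatter. Nothing measured here speaks to a longer chain at that place, so the expectation rests on that single step alone. Compound 4 is therefore expected to show a step of a 1.1-fold higher number from compound 3 to compound 4 (0.06 log units; within the scatter) that stays within the scatter, in no clear direction. The estimate for compound 4 in this assay is 25 nM, with a range from 10 nM to 65 nM.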

Compound 4, half-maximal inhibitory concentration: 14 nM
The estimate for compound 4 lay 1.8-fold (0.25 log units) above the measured number; the range from low to high includes it.
By their numbers in this assay, from the lowest: compounds 4, 2 and 3 (each within the scatter of the next); then compound 1.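

In this assay, going from methyl to propyl at this place gives no change that can be read (a 1.6-fold lower number from compound 3 to compound 4 (0.20 log units; within the scatter)), and compound 4 also cannot be told apart from the unsubstituted phenyl of compound 2 (a 1.1-fold lower number from compound 2 to compound 4 (0.06 log units; within the scatter)), so hydrogen, methyl and propyl on this aromatic carbon all give numbers within the scatter of one another. The clear gap to the propyl amide persists with the larger 4-propylphenyl group on the carbonyl carbon (a 13-fold lower number from compound 1 to compound 4 (1.10 log units; beyond the scatter)), in line with phenyl and 4-methylphenyl. Nothing shown here gives a reason for any of these steps.

What the compounds shown leave open is whether a longer chain, such as hexyl, would also stay within the scatter of propyl. They also do not tell whether an amine or a carboxylic acid in place of the propyl would keep these numbers.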